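This account rests on a few compounds, and the source may have more. Where it says the series, first, only, none or still open, it means among the compounds named here.

Measured in a functional assay on A549 cells (Homo sapiens) for inhibition; on this read-out lower numbers stand for stronger inhibition and higher numbers for weaker inhibition:

- Compound 1 `CC(C)c1cc(-c2n[nH]c(=O)n2-c2cccc(C(=O)NCCCCCC(=O)NO)c2)c(O)cc1O`: 4600 nM
- Compound 2 `CC(C)c1cc(-c2n[nH]c(=O)n2-c2ccc(C(=O)NCCCC(=O)NO)cc2)c(O)cc1O`: 4600 nM

Compound 1 stands level with compound 2, with no difference beyond the scatter. Compound 3 `CNC(=O)CCCCCCCNC(=O)c1cccc(-n2c(-c3cc(C(C)C)c(O)cc3O)n[nH]c2=O)c1` has not yet been measured. Relative to compound 1, it carries 2-(methylcarbamoyl)ethyl in place of hydroxycarbamoyl on a saturated chain carbon, five bonds along the chain from an amide-type nitrogen. Going by the values given here, no measured pair shows what this exchange does, so any forecast is uncertain. A moderate weakening in this assay is expected, meaning a move toward higher numbers. The expected change is a 2.0-fold higher number from compound 1 to compound 3 (0.29 log units; within the scatter). Compound 3 is estimated at 9000 nM, with an expected range of 3000 nM to 30000 nM.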

Compound 3, half-maximal inhibitory concentration: 4600 nM
For compound 3 the middle estimate is 2.0-fold (0.29 log units) above the measured one; measured number inside the range.
By their numbers in this assay, from the lowest: compounds 1, 2 and 3 (each within the scatter of the next).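

In this assay, exchanging hydroxycarbamoyl for 2-(methylcarbamoyl)ethyl on this saturated chain carbon gives no change at the digits printed from compound 1 to compound 3 (within the scatter). Compounds 1 and 2 both carry hydroxycarbamoyl, so only compound 3 shows that the read-out at this position does not depend on keeping that group. No supporting measurement explains why the exchange leaves the number in place. Going by these compounds, it remains open whether a carboxylic acid or an amine at the end of the chain would read the same way. A shorter chain ending in the methylcarbamoyl group is also an open case.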